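The source may hold more compounds than are shown below. What is called first, only, known or untested is meant among the compounds shown, and "the series" means these compounds.

Measured compounds in an ADME assay on Vero cells (Chlorocebus sabaeus) for cytotoxicity, read by MTT assay, with a stated time of 72 h; a lower number here means that less compound is tolerated, a higher number that more compound is tolerated:

compound 1 `CCOc1ccc(C(=O)/C=C/c2ccc(C(=O)Nc3cccc(-c4cc(C(=O)OC)no4)c3)cc2)cc1` — in this assay compound 1 gives > 40 ug/mL, a limit of the assay rather than a number.
compound 2 `COC(=O)c1cc(-c2cccc(NC(=O)c3ccc(/C=C/C(=O)c4cc(F)ccc4F)cc3)c2)on1` — in this assay compound 2 gives > 40 ug/mL, again only a limit.
compound 3 `COC(=O)c1cc(-c2cccc(NC(=O)c3ccc(/C=C/C(=O)c4ccc(F)cc4F)cc3)c2)on1` — in this assay compound 3 gives > 40 ug/mL, again only a limit.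

Compound 2 therefore stands on no number of its own: it sits at the limit, as do the two other values shown (the limit of > 40 ug/mL in this assay, at which 3 of the 3 values shown sit). The steps among the measured compounds, a step that the two limits leave unreadable from compound 1 to compound 2, a step that the two limits leave unreadable from compound 1 to compound 3 and a step that the two limits leave unreadable from compound 2 to compound 3, are all left unreadable by their limits, so no size can be taken from them.

Compound 4 `COC(=O)c1cc(-c2cccc(NC(=O)c3ccc(/C=C/C(=O)c4ccc([N+](=O)[O-])cc4)cc3)c2)on1` is not yet measured. The change from compound 2 is 4-nitrophenyl in place of 2,5-difluorophenyl on a carbonyl carbon.

For the measured compounds named here, the only bearing the measured steps have on this change is that three aryl variations on the carbonyl carbon have all sat at the limit. No readable step exists in either direction, so no step beyond the scatter is expected. Compound 4 is expected to sit again at the limit, estimated at 50 ug/mL (range 25 ug/mL to 100 ug/mL), which means an expected step that the limit leaves unreadable from compound 2 to compound 4.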

Compound 4, half-maximal cytotoxic concentration: > 20 ug/mL
Compound 4: a limit, no number; the forecaster's own chance of this, stated with the estimate: 80%; the middle value does not contradict the limit.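

In this assay, for the compounds shown here, compound 4 gives > 20 ug/mL, which is a limit, so no step from compound 1, compound 2 or compound 3 to compound 4 can be read. The compounds shown leave open whether changing the aryl group on the carbonyl carbon alters cytotoxicity at all.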